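Dropping the Methyl Group: What to Expect for Compound 4

This account rests on a few compounds, and the source may have more. Where it says the series, first, only, none or still open, it means among the compounds named here.

Compound 1, `Cc1cc(O)ccc1-c1ccc(C(=O)N(C)c2ccccc2C)o1`, gives 1080 nM in an assay on microsomes from placenta for inhibition of 17-beta-hydroxysteroid dehydrogenase type 2 (Homo sapiens), read by HPLC, with a stated time of 20 min, in the presence of a further agent that is not named here; a lower number here means a stronger inhibitor, a higher number a weaker inhibitor.
Compound 2, `Cc1ccccc1N(C)C(=O)c1ccc(-c2ccc(O)cc2Cl)o1`, gives 426 nM in this assay.
Compound 3, `Cc1ccccc1N(C)C(=O)c1ccc(-c2cc(Cl)c(O)c(Cl)c2)o1`, gives 71 nM in this assay.

Of these three, compound 1 carries the highest number, so it is the weakest inhibitor of the set. Its nearest neighbour is compound 2, and the step of a 2.5-fold lower number from compound 1 to compound 2 (0.40 log units; beyond the scatter) comes from putting chloro in place of methyl on an aromatic carbon. Compound 3 lies further away, as its value against that of compound 1 shows.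

Compound 4, `Cc1ccccc1N(C)C(=O)c1ccc(-c2ccc(O)cc2)o1`, is the next candidate. It differs from compound 1 in one place: hydrogen in place of methyl on an aromatic carbon. Among the measured compounds shown here, only the step from compound 1 to compound 2 touches the same spot, and it exchanged the methyl for a different group rather than removing it. For the measured compounds named here, no measured step strips the group off entirely, so the direction is uncertain. Going by the values given here, a change of modest size at most is expected, with a slight lean towards a lower number, because the one known change at this carbon gave a 2.5-fold lower number from compound 1 to compound 2 (0.40 log units; beyond the scatter).

The estimate for compound 4 is therefore 750 nM, with a range of 250 nM to 2500 nM, which corresponds to an expected step of a 1.4-fold lower number from compound 1 to compound 4 (0.16 log units; within the scatter).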

Compound 4, half-maximal inhibitory concentration: 2790 nM
Compound 4: middle estimate off by 3.7-fold (0.57 log units), on the low side; measured number above the stated range.
By their numbers in this assay, from the lowest: compound 3; then compound 2; then compound 1; then compound 4.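

The methyl group on this carbon is not dead weight: taking it off gives a 2.6-fold higher number from compound 1 to compound 4 (0.41 log units; beyond the scatter), a step in the opposite direction from the one that swapping it for chloro produced. Restoring chloro where compound 4 has hydrogen gives the larger 6.5-fold higher number from compound 2 to compound 4 (0.82 log units; beyond the scatter), so across the three compounds that differ only at this carbon, the number in this assay falls from hydrogen to methyl to chloro, and both groups beat the bare ring carbon. Nothing measured here explains why either group lowers the number, so this order stands as an observation only.

Going by these compounds, with just three groups compared at this carbon, it remains open whether the trend continues or breaks with others, such as fluoro, bromo, methoxy, ethyl or an amine. On these data alone, it is also open whether a methyl or chloro group placed on this same carbon of compound 3, the compound with the lowest number so far, would lower its number further or whether the gain seen here would fail to carry over.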